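This account rests on a few compounds, and the source may have more. Where it says the series, first, only, none or still open, it means among the compounds named here.

Measured in a functional assay on A-431 cells (Homo sapiens) for inhibition, read by sulforhodamine B assay, with a stated time of 2 days; a higher number here means a weaker inhibitor of growth, a lower number a stronger inhibitor of growth:
- compound 1 `CC1=C(C(=O)Nc2cccc([N+](=O)[O-])c2)C(c2ccc(O)cc2O)NC(SCc2ccccc2)=N1`: > 100000 nM (a limit)
- compound 2 `CC1=C(C(=O)Nc2cccc([N+](=O)[O-])c2)C(c2ccc(O)cc2O)NC(N/N=C/c2ccco2)=N1`: 2910 nM

Among the compounds with values here, compound 2 gives 2910 nM, the only actual number so far. Compound 1 reports only a limit, > 100000 nM.

The next compound is compound 3 `CC1=C(C(=O)Nc2cccc([N+](=O)[O-])c2)C(c2ccc(O)cc2O)NC(N/N=C/c2cccs2)=N1`, with thiophen-2-yl in place of furan-2-yl on a carbon with a double bond to nitrogen. Both groups are five-membered aromatic rings with 1 hetero atom, so the change is confined to that hetero atom.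

Within the data shown here, only one measured step bears on this change: an at least 34-fold lower number from compound 1 to compound 2 (1.53 log units; beyond the scatter). It is large, but its size is only a bound, set by the limit of > 100000 nM in this assay, at which 1 of the 2 values shown sits. That step also exchanged a whole group at this place, so it shows that the place matters without giving a size for a swap of one ring for the other. Set against compound 2 at 2910 nM, the much smaller change in compound 3 leads to an expectation of no step beyond the scatter in this assay, and no direction is favoured.

The expected step is a 1.1-fold lower number from compound 2 to compound 3 (0.03 log units; within the scatter).

For compound 3 the estimated value is 2700 nM, with an expected range of 900 nM to 8500 nM.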

Compound 3, concentration for 50% growth inhibition: 19100 nM
Estimate against measurement, compound 3: 7.1-fold (0.85 log units) below, outside the stated range (above it).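

In this assay, the hetero atom of the five-membered aromatic ring is not a neutral exchange at this place: thiophen-2-yl in place of furan-2-yl on a carbon with a double bond to nitrogen gives a 6.6-fold higher number from compound 2 to compound 3 (0.82 log units; beyond the scatter). Within the data shown here, the earlier step showed only that the whole group matters, whereas this one shows that the series separates two rings with the same counts of heavy atoms, donors and acceptors, and that furan-2-yl is the better of the two here. The group carrying thiophen-2-yl still keeps a difference from the group in compound 1, an at least 5.2-fold lower number from compound 1 to compound 3 (0.71 log units; beyond the scatter), but compound 1 stands at a limit, so the size of that step is only a bound: the limit of > 100000 nM in this assay, at which 1 of the 3 values shown sits.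

As far as these compounds go, whether a pyrrol-2-yl or a pyridin-2-yl ring at this place would read like furan-2-yl or like thiophen-2-yl stays open, and with it whether the hetero atom alone sets the step. Also open, from the compounds shown here alone, is how a plain amine on that carbon, with no ring at all, would compare with these groups.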